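The source may hold more compounds than are shown below. What is called first, only, known or untested is meant among the compounds shown, and "the series" means these compounds.

Compound 1, `C[C@@H](NC(=O)c1ccc(C#Cc2cc(F)cc(F)c2)cn1)C(C)(C)O` — 37.9%
Compound 2, `Cc1ccccc1C#Cc1ccc(C(=O)N[C@H](C)C(C)(C)O)nc1` — 24.1%
Compound 3, `Cc1cccc(C#Cc2ccc(C(=O)N[C@H](C)C(C)(C)O)nc2)c1` — 20.8%

In an ADME assay on HEK293 cells for agonist activity at metabotropic glutamate receptor 5 (Rattus norvegicus), read by fluorescence and calcium flux (a lower number here means a smaller maximal response, a higher number a larger maximal response), compound 3 gives 20.8%, the lowest of the three numbers. Its nearest neighbour is compound 2 with 24.1%, and the step of a number 3.3 percentage points lower from compound 2 to compound 3 (within the scatter) lies within the scatter. The step of a number 17.1 percentage points lower from compound 1 to compound 3 (beyond the scatter) is beyond the scatter, as is a number 13.8 percentage points lower from compound 1 to compound 2 (beyond the scatter).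

Compound 4, `C[C@@H](NC(=O)c1ccc(C#CC2CCCC2)cn1)C(C)(C)O`, differs from compound 3 in one place: cyclopentyl in place of 3-methylphenyl on a triple-bonded carbon. All three measured steps change the group on the triple-bonded carbon, and they are the ones that bear on this step. Swapping one aromatic ring for another moved the efficacy by a modest amount at most, and the two methylphenyl variants sit within the scatter of each other. No measured step replaces the aromatic ring with a non-aromatic one, so the direction of this change is not shown by the data. On that basis a step of about a number 1.2 percentage points higher from compound 3 to compound 4 (within the scatter) in this assay is expected, which means a value for compound 4 estimated at 22%, with a range from 8% to 40%.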

Compound 4, largest response reached (reported as efficacy), in percent of the reference or control that the assay uses: 14.8%
The estimate for compound 4 lay 7.2 percentage points above the measured number; the range from low to high includes it.
By their numbers in this assay, from the lowest: compounds 4, 3 and 2 (each within the scatter of the next); then compound 1.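

In this assay the group on the triple-bonded carbon need not be aromatic: cyclopentyl gives a result that cannot be told apart from either methylphenyl compound (a number 6 percentage points lower from compound 3 to compound 4 (within the scatter); a number 9.3 percentage points lower from compound 2 to compound 4 (within the scatter)). Against the 3,5-difluorophenyl group the change does count (a number 23.1 percentage points lower from compound 1 to compound 4 (beyond the scatter)), so compound 1 remains the only compound set apart from the others. Among these four compounds, the loss of the aromatic ring therefore shows up only in the comparison with compound 1, and nothing measured here explains the result.

Going by these compounds, it stays open whether the difference for compound 1 goes with its fluorine atoms or with its aromatic ring, which a plain phenyl or a difluorocyclopentyl group could help to separate. On these data alone, how an open chain such as tert-butyl or a basic amine would fare on the triple-bonded carbon also stays open.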